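Methyl on the chain carbon of compound 2

This account rests on a few compounds, and the source may have more. Where it says the series, first, only, none or still open, it means among the compounds named here.

Of the compounds shown here, two have been read so far. In a functional assay on the whole organism for agonist activity, with Mus musculus as the target (on this read-out lower numbers stand for an effect already at smaller amounts and higher numbers for an effect only at larger amounts of compound), compound 1 `COC(=O)N(C)C(C)C#CCn1ccnc1` gives 8 mg/kg as a true number. In this assay compound 2 `CCOC(=O)N(C)CC#CCn1ccnc1` gives > 100 mg/kg and this is only a limit of the assay, not a number. Compound 2 therefore stands at the limit of the read-out, with no measured dose to start from.

Compound 3 `CCOC(=O)N(C)C(C)C#CCn1ccnc1` derives from compound 2 by methyl in place of hydrogen on a saturated chain carbon bound to an amide-type nitrogen and a triple-bonded carbon. Within the data shown here, no measured step sizes this change directly, so the expectation leans on compound 1 at 8 mg/kg as the only number available. In this assay the expected at least 6.6-fold lower number from compound 2 to compound 3 (0.82 log units; beyond the scatter) is a large one towards smaller doses, beyond the scatter. For compound 3 the estimate is 15 mg/kg and the value is expected to fall from 4 mg/kg to 60 mg/kg on this read-out.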

Compound 3, dose for half-maximal effect: > 100 mg/kg
Compound 3 ended at the assay's limit (the forecaster's own chance of this, stated with the estimate: 10%); middle value at least 6.6-fold (0.82 log units) from the limit.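

In this assay compound 3 gives > 100 mg/kg, which is a limit of the assay and not a number. The effect of methyl in place of hydrogen on a saturated chain carbon bound to an amide-type nitrogen and a triple-bonded carbon cannot be read, because both compounds of that pair end at the same limit: the limit of > 100 mg/kg in this assay, at which 2 of the 3 values shown sit.

The one readable comparison lies at the other place, where methyl in place of hydrogen on a saturated chain carbon bound to an oxygen next to a carbonyl group gives an at least 12-fold higher number from compound 1 to compound 3 (1.09 log units; beyond the scatter), so the methyl on the chain carbon, present in both of these compounds, does not by itself secure a measurable dose in this pair.

As far as these compounds go, whether that chain methyl has any effect at all when the larger group stays on the oxygen remains open, since compound 2 and compound 3 give no size for it. Also open, from the compounds shown here alone, is how far the read-out shifts with a propyl chain on that oxygen, or with an ethyl group in place of the methyl on the chain carbon.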